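The source may report more compounds than this note shows. Statements on the series, on what has been measured and on what is new or still open speak of the compounds shown alone.

Of the compounds shown here, two with a shared core have been measured so far in a functional assay on SW-620 cells (Homo sapiens) for cytotoxicity, read by MTT assay, with a stated time of 72 h; on this read-out higher numbers stand for weaker inhibition and lower numbers for stronger inhibition. In it, compound 1 (`COc1cccc(/C=C2\CCC/C(=C\c3cccc(Cl)c3)C2=O)c1OC`) gives 9100 nM, and compound 2 (`COc1cccc(/C=C2\CCC/C(=C\c3cccc(O)c3)C2=O)c1OC`) gives 6400 nM. Among the compounds with values here, compound 2 therefore stands within the scatter of its only measured neighbour. Within the data shown here, the single step between them, hydroxy in place of chloro on an aromatic carbon, is a 1.4-fold lower number from compound 1 to compound 2 (0.15 log units; within the scatter).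

The next compound is compound 3 (`COc1cccc(/C=C2\CCC/C(=C\c3ccc(Cl)c(Cl)c3)C2=O)c1OC`), and the change that leads to it is 3,4-dichlorophenyl in place of 3-hydroxyphenyl on a double-bonded chain carbon bound to a double-bonded ring carbon. Among the measured compounds shown here, the one measured step offers the only guide, since it also exchanges hydroxy and chloro, and it stayed within the scatter. For the measured compounds named here, no measured compound shows what a second chlorine does. In this assay, the expected change is therefore no step beyond the scatter, and the estimated step is a 1.1-fold higher number from compound 2 to compound 3 (0.04 log units; within the scatter). For compound 3, the expected value is 7000 nM, with an estimated range of 2500 nM to 20000 nM.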

Compound 3, half-maximal inhibitory concentration: 10000 nM
For compound 3 the middle estimate is 1.4-fold (0.15 log units) below the measured one, within the range that was stated.
By their numbers in this assay, from the lowest: compounds 2, 1 and 3 (each within the scatter of the next).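

In this assay, 3,4-dichlorophenyl in place of 3-hydroxyphenyl on this double-bonded chain carbon gives a 1.6-fold higher number from compound 2 to compound 3 (0.19 log units; within the scatter), so losing the hydroxy group, with its hydrogen-bond donor and acceptor, and gaining two chlorines leaves the two compounds within the scatter of each other. The earlier compounds shown here could not show what a second chlorine does, but chloro in place of hydrogen on an aromatic carbon now gives a 1.1-fold higher number from compound 1 to compound 3 (0.04 log units; within the scatter), also within the scatter. Nothing measured here offers an explanation for these small steps.

From the compounds shown here alone, whether an amine or a carboxylic acid on this aromatic ring would give a step beyond the scatter in this assay remains open. Going by these compounds, all three compounds also keep the rest of the shared core unchanged, so what that part contributes is unknown.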